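Nitro in Place of Cyano: Two Steps Compared

The source may report more compounds than this note shows. Statements on the series, on what has been measured and on what is new or still open speak of the compounds shown alone.

Of the compounds shown here, three have been measured in a physicochemical assay for solubility, read by spectrophotometry, in phosphate buffer, with a stated time of 18 h, at pH 7.4; a lower number here means a less soluble compound, a higher number a more soluble compound. Compound 1 `CCc1ccc(-c2nc3c(c(C)nn3-c3ccccc3)c(-c3ccccc3[N+](=O)[O-])c2C#N)cc1` gives 1200 nM, compound 2 `CCc1ccc(-c2nc3c(c(C)nn3-c3ccccc3)c(-c3ccccc3C#N)c2C#N)cc1` gives 2400 nM, and compound 3 `Cc1nn(-c2ccccc2)c2nc(-c3ccc(C#N)cc3)c(C#N)c(-c3ccccc3O)c12` gives 1700 nM. Compounds 2 and 1 differ in one place: nitro in place of cyano on an aromatic carbon. That change gave a 2.0-fold lower number from compound 2 to compound 1 (0.30 log units; within the scatter). The difference between the cores of compound 2 and compound 3 is not broken down here; in this assay compound 3 and compound 2 give numbers that lie within the scatter of each other.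

Compound 4 `Cc1nn(-c2ccccc2)c2nc(-c3ccc([N+](=O)[O-])cc3)c(C#N)c(-c3ccccc3O)c12` has not yet been measured. It differs from compound 3 by the same kind of change: nitro in place of cyano on an aromatic carbon. The surroundings are not the same word for word: in compound 1 the nitro group sits ortho to a large group, whereas in compound 4 it sits para to a large group. Because the earlier step was a 2.0-fold lower number from compound 2 to compound 1 (0.30 log units; within the scatter), a step of similar size and direction is expected here. On that footing the expected step is a 1.9-fold lower number from compound 3 to compound 4 (0.28 log units; within the scatter). Compound 4 is therefore estimated at 900 nM in this assay, with 400 nM to 2000 nM as the expected range.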

Compound 4, solubility: 6000 nM
The estimate for compound 4 lay 6.7-fold (0.82 log units) below the measured number, and the stated range ends below it.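

In this assay, swapping nitrile for nitro as 4-cyanophenyl to 4-nitrophenyl gave a 3.5-fold higher number from compound 3 to compound 4 (0.55 log units; beyond the scatter), while the same kind of swap on the core of compound 2 gave a 2.0-fold lower number from compound 2 to compound 1 (0.30 log units; within the scatter). The two steps point in opposite directions and only the new one lies beyond the scatter, so in these two pairs the result on one core did not carry over to the other. With a single pair per core, this shows that the change cannot be moved between these cores on trust, but it sets no rule for the series, and nothing given here explains the difference between the two steps.

Still open, as far as these compounds go, is whether an amine or a carboxylic acid at the place the nitro group holds in compound 4 would give a number nearer that of compound 3 or compound 4. A further pair on another core would also be needed to tell which of the two steps is the more typical.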